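The source may report more compounds than this note shows. Statements on the series, on what has been measured and on what is new or still open speak of the compounds shown alone.

Compound 1 `Cc1onc(NS(=O)(=O)c2cccc3c(N(C)C)cccc23)c1C`: 60 nM
Compound 2 `Cc1noc(NS(=O)(=O)c2cccc3c(N(C)C)cccc23)c1Cc1ccccc1`: 50000 nM
Compound 3 `Cc1cnoc1NS(=O)(=O)c1cccc2c(N(C)C)cccc12`: 4900 nM

Three compounds share the same sulfonamide core and differ only in the five-membered ring attached to the sulfonamide nitrogen. In an assay on VSM-A10 cells for antagonist activity at Endothelin-1 receptor (Rattus norvegicus) (on this read-out lower numbers stand for stronger inhibition and higher numbers for weaker inhibition), compound 1 gives 60 nM, compound 2 gives 50000 nM and compound 3 gives 4900 nM. Compound 3 therefore stands second highest of the three numbers, nearer to compound 2 than to compound 1. For the measured compounds named here, the only step between two compounds that differ in one place is an 82-fold higher number from compound 1 to compound 3 (1.91 log units; beyond the scatter), which shows that how the ring is attached and decorated matters greatly here.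

Compound 4 `CCc1noc(NS(=O)(=O)c2cccc3c(N(C)C)cccc23)c1C` differs from compound 3 by ethyl in place of hydrogen on an aromatic carbon. Going by the values given here, no measured step matches this change directly, so the expectation rests loosely on the two values around it: compound 1, with two small groups on its ring, gives a low number, while compound 2, with a large group on its ring, gives a high number. A modest improvement is expected for compound 4, with wide uncertainty. For compound 4 the expected step is a 2.5-fold lower number from compound 3 to compound 4 (0.39 log units; beyond the scatter). Compound 4 is estimated at 2000 nM, with a range from 400 nM to 10000 nM.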

Compound 4, half-maximal inhibitory concentration: 1170 nM
The estimate for compound 4 lay 1.7-fold (0.23 log units) above the measured number, within the range that was stated.
By their numbers in this assay, from the lowest: compound 1; then compound 4; then compound 3; then compound 2.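

In this assay, ethyl in place of hydrogen on the aromatic carbon next to the ring nitrogen gives a 4.2-fold lower number from compound 3 to compound 4 (0.62 log units; beyond the scatter), so a group at this position is compatible with stronger inhibition, and here it brings a modest gain. The gain remains partial, however: the change from 4,5-dimethyl-1,2-oxazol-3-yl to 3-ethyl-4-methyl-1,2-oxazol-5-yl still gives a 20-fold higher number from compound 1 to compound 4 (1.29 log units; beyond the scatter), so this ethyl does not bring the number back to that of compound 1. Nothing available here explains why ethyl lowers the number.

From the compounds shown here alone, at this position, only hydrogen and ethyl can be compared, so it remains open whether a single methyl would give part of the gain or a longer chain such as propyl would add to it. How an amine or a carboxylic acid on the same carbon would behave is also unknown.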